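Swapping a Hexyl Chain for Pyridin-4-yl

This account rests on a few compounds, and the source may have more. Where it says the series, first, only, none or still open, it means among the compounds named here.

Compound 1, with the structure `CCCCCC/C=C/C[C@H]1C[C@@H]([C@@H](O)c2ccccc2)CO[C@@H]1c1ccccc1`, is the reference point here. For the measured compounds named here, in a functional assay on HeLa cells (Homo sapiens) for cytotoxicity, read by WST assay, with a stated time of 48 h (on this read-out lower numbers stand for stronger inhibition and higher numbers for weaker inhibition), compound 1 gives 7400 nM, the lowest of the three numbers measured so far. The two compounds measured alongside it share the same core but carry more substituents on their rings. Compound 2, `COc1ccc(/C=C/C[C@@H]2C[C@@H]([C@@H](O)c3ccc(OC)c(OC)c3)CO[C@H]2c2ccc(OC)c(OC)c2)cc1`, gives 17100 nM in this assay, a higher number than compound 1 by a margin beyond the usual scatter. Compound 3, `COc1ccc([C@H](O)[C@H]2CO[C@H](c3ccc(OC)c(OC)c3)[C@@H](C/C=C/c3ccc(OC)c(OC)c3)C2)cc1`, gives 46000 nM in this assay, higher still and also beyond the scatter. Neither compound 2 nor compound 3 differs from compound 1 in a single place, so no isolated step can be read from them.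

Compound 4, `O[C@@H](c1ccccc1)[C@H]1CO[C@H](c2ccccc2)[C@@H](C/C=C/c2ccncc2)C1`, has not yet been measured. Its difference from compound 1 is a single change: pyridin-4-yl in place of hexyl on a double-bonded chain carbon bound to a double-bonded chain carbon. Going by the values given here, no measured pair shows this same change, so the expectation rests on the general spread of the three known numbers. The step of a 1.6-fold higher number from compound 1 to compound 4 (0.21 log units; within the scatter) is expected to be a modest rise in the number, close to the edge of the scatter rather than far beyond it. For compound 4 the estimated value in this assay is 12000 nM, within a range from 4000 nM to 40000 nM.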

Compound 4, half-maximal inhibitory concentration: > 100000 nM
Compound 4: only a limit was reported; the forecaster's own chance of this, stated with the estimate: 10%; middle value at least 8.3-fold (0.92 log units) away from the limit.
By their numbers in this assay, from the lowest: compound 1; then compound 2; then compound 3. At a limit, above all of these: compound 4.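

For the compounds shown here, the swap of hexyl for pyridin-4-yl on a double-bonded chain carbon bound to a double-bonded chain carbon is the first change in this set that can be read on its own, and in this assay it gives an at least 13-fold higher number from compound 1 to compound 4 (1.13 log units; beyond the scatter). Hexyl and pyridin-4-yl carry the same number of heavy atoms, so this position responds strongly to what the group is, even when the atom count stays the same. The result for compound 4 is a limit of the assay and not a number, which leaves the true size of the step unfixed, and it is the only such result in the set: the limit of > 100000 nM in this assay, at which 1 of the 4 values shown sits.

The compounds shown do not separate the effect of having a ring at this place from the effect of having a ring nitrogen, a question that cyclohexyl or a plain phenyl ring in the same place could address. They also leave open how much of the chain can change before the number rises, for example with a shorter chain or a hexyl chain ending in an amine, and they say nothing about why the number rises.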